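Swapping the Nitro Ring for a Dichlorophenyl Ring

A few compounds are considered here, and "the series" means these few. Any claim that something is new, unique, unknown or untested is made for them only; others in the source may bear on it.

Measured so far:
compound 1, `O=C(O)c1ccc(C(=O)c2ccc(C(=O)c3ccc(O)cc3)cc2)cc1`: 22 nM
compound 2, `O=C(O)c1ccc(C(=O)c2ccc(C(=O)c3ccc([N+](=O)[O-])cc3)cc2)cc1`: 100 nM

Two compounds share a core of three benzene rings joined by two carbonyl groups, with a carboxylic acid at one end; they differ only in the group on the far ring. In an assay on CHO cells for inhibition of 3-oxo-5-alpha-steroid 4-dehydrogenase 2 (Homo sapiens) (a lower number here means a stronger inhibitor, a higher number a weaker inhibitor), compound 1 gives 22 nM, while compound 2 gives 100 nM. Among the compounds with values here, compound 2 therefore holds the higher of the two numbers, and the single measured step, a 4.5-fold higher number from compound 1 to compound 2 (0.66 log units; beyond the scatter), is what separates it from compound 1, produced by nitro in place of hydroxy on an aromatic carbon.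

The next compound, compound 3, `O=C(O)c1ccc(C(=O)c2ccc(C(=O)c3ccc(Cl)c(Cl)c3)cc2)cc1`, is made from compound 2 by the exchange (3,4-dichlorophenyl in place of 4-nitrophenyl on a carbonyl carbon). Within the data shown here, no measured step covers this exact exchange; the only step known concerns a different substituent on the same ring and was modest in size. On that basis a change of comparable, modest size is expected, with the direction uncertain, so the estimated step is a 1.7-fold lower number from compound 2 to compound 3 (0.22 log units; within the scatter). For compound 3 the estimate in this assay is 60 nM, within a range of 15 nM to 250 nM.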

Compound 3, inhibition constant: 35 nM
Beside the measured number, compound 3's estimate is 1.7-fold (0.23 log units) above it, and the stated range covers the measured number.
By their numbers in this assay, from the lowest: compounds 1 and 3 (each within the scatter of the next); then compound 2.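

In this assay, the 4-nitrophenyl group is not the only alternative to the 4-hydroxyphenyl group that can be placed on this carbonyl carbon: exchanging it for 3,4-dichlorophenyl gives a 2.9-fold lower number from compound 2 to compound 3 (0.46 log units; beyond the scatter) and so recovers much of the ground lost with the nitro group. The entering ring carries no hydroxy group, yet the comparison with the hydroxy compound gives a 1.6-fold higher number from compound 1 to compound 3 (0.20 log units; within the scatter) and leaves compound 1 and compound 3 indistinguishable in this assay, so a hydroxy group on this ring is not needed for a number in this range. Nothing available explains why the chlorine-bearing ring and the nitro-bearing ring give different numbers.

Whether one chlorine would serve as well as two remains an open question, since the step combines the loss of the nitro group with the arrival of both chlorines. From the compounds shown here alone, how an amine or a methoxy group on this ring would compare, and whether a methyl ester could replace the carboxylic acid on the shared core, also remains unknown.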